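A Second Chloro Added: Expecting Weaker Cytotoxicity

The source may report more compounds than this note shows. Statements on the series, on what has been measured and on what is new or still open speak of the compounds shown alone.

Compound 1 `O=[N+]([O-])c1ccc(Oc2c(Cl)cc(S(=O)(=O)N/C(=N\O)Nc3ccc(Cl)cc3)cc2Cl)cc1` and compound 2 `O=[N+]([O-])c1ccc(Oc2c(Cl)cc(S(=O)(=O)N/C(=N\O)Nc3ccc(Cl)cc3)cc2Cl)c(Cl)c1` share one core and differ in a single spot: chloro in place of hydrogen on an aromatic carbon. In a functional assay on HepG2 cells (Homo sapiens) for cytotoxicity (on this read-out higher numbers stand for weaker inhibition and lower numbers for stronger inhibition), compound 1 gives 22 ug/mL, while compound 2 gives 49 ug/mL. That single change produced a 2.2-fold higher number from compound 1 to compound 2 (0.35 log units; beyond the scatter).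

Compound 3 `Cc1ccc(S(=O)(=O)/N=C(\S)Nc2ccc(Cl)cc2)cc1` is built on a different core; the difference between the two cores is not broken down here. In this assay compound 3 gives 232 ug/mL, the highest of the three numbers, and its gaps to compound 1 and to compound 2 both lie beyond the scatter.

Compound 4 `Cc1ccc(S(=O)(=O)/N=C(\S)Nc2ccc(Cl)c(Cl)c2)cc1` has not yet been measured. It differs from compound 3 by chloro in place of hydrogen on an aromatic carbon. This is the same kind of change as that from compound 1 to compound 2, but not the same: in the measured pair the entering chloro sits ortho to a large group and meta to a nitro group, whereas in compound 4 it sits ortho to a chloro group and meta to a large group, and the surrounding cores are different.

Within the data shown here, only one measured example of this kind of change exists, and it was modest, so for compound 4 a step of about a 1.5-fold higher number from compound 3 to compound 4 (0.18 log units; within the scatter) is expected, resting on the step of a 2.2-fold higher number from compound 1 to compound 2 (0.35 log units; beyond the scatter). Compound 4 is accordingly expected to give roughly 350 ug/mL, most likely between 150 ug/mL and 800 ug/mL, with the caveat that compound 3 already gives a high number and the assay may report only a limit.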

Compound 4, half-maximal inhibitory concentration: 120 ug/mL
Compound 4: the middle estimate sits 2.9-fold (0.46 log units) above what was measured, and the stated range ends above it.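

On the core of compound 3, the same change gives a 1.9-fold lower number from compound 3 to compound 4 (0.29 log units; within the scatter) in this assay, so on this core the added chloro leaves the number within the usual scatter of repeated measurements. Set beside the earlier step, the change does not carry over from one core to the other with a fixed size: the same change on two cores in this assay, a 2.2-fold higher number (0.35 log units; beyond the scatter) from compound 1 to compound 2 and a 1.9-fold lower number (0.29 log units; within the scatter) from compound 3 to compound 4, 4.3-fold (0.63 log units) apart, beyond the scatter of two such steps This shows that a step measured on one core of this series was a poor guide to the step on the other, but it does not show why, as the two pairs differ both in their core and in the place where the chloro enters, and two pairs cannot set a rule for the whole series.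

The compounds shown leave open whether the core or the place of the chloro matters more, a question that a chloro entering at the matching place on both cores could help to settle. They also leave open how a different group at the position taken by the new chloro in compound 4, such as a fluoro, a methoxy or an amine, would behave on either core.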